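A few compounds are considered here, and "the series" means these few. Any claim that something is new, unique, unknown or untested is made for them only; others in the source may bear on it.

Two compounds of one shared core have been examined in a functional assay on Urethra with Alpha-1A adrenergic receptor (Oryctolagus cuniculus) as the target; a lower number here means a smaller maximal response, a higher number a larger maximal response. Compound 1 `CS(=O)(=O)Nc1c(O)ccc2c1CCCC2c1c[nH]cn1` gives 104%. Compound 2 `CN(c1cccc2c1CCCC2c1c[nH]cn1)S(C)(=O)=O` gives 79%, the lower of the two numbers, with compound 1 standing higher by a gap that lies beyond the usual scatter. Compound 3 `Nc1cccc2c1CCCC2c1c[nH]cn1` has not yet been measured; it differs from compound 2 by amino in place of methyl(methylsulfonyl)amino on an aromatic carbon. Because compound 2 gives 79% in this assay, a modest upward step a number 11 percentage points higher from compound 2 to compound 3 (beyond the scatter) is expected, though it may fall within the scatter. Compound 3 is estimated to give 90%, in a range from 65% to 112%.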

Compound 3, largest response reached (reported as efficacy), in percent of the reference or control that the assay uses: 84%
For compound 3 the middle estimate is 6 percentage points above the measured one; the range from low to high includes it.
By their numbers in this assay, from the lowest: compounds 2 and 3 (each within the scatter of the next); then compound 1.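

In this assay, amino in place of methyl(methylsulfonyl)amino on this aromatic carbon amounts to a number 5 percentage points higher from compound 2 to compound 3 (within the scatter). Compound 2 and compound 3 thus cannot be told apart here, even though six heavy atoms leave and one enters, and neither the sulfonyl oxygens nor the methyl on nitrogen is needed for a response of this size. Nothing available bears on the reason for this. Compound 1 differs from compound 3 in more than one place, so its value cannot be assigned to one group. From the compounds shown here alone, how a hydroxyl or an acetamido group on this same carbon would read remains open.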